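Methyl for fluoro: from compound 1 to compound 3

The compounds below may be only part of what the source reports. "The series", "measured", "known", "first", "only" and "open" are said of these compounds alone.

Measured in a functional assay on SW480 cells (Homo sapiens) for antiproliferative activity, with a stated time of 72 h; a higher number here means a weaker inhibitor, a lower number a stronger inhibitor:
- compound 1 `O=C(COc1ccc(CN2CC=C(c3c[nH]c4ccc(F)cc34)CC2)cc1)NO` gives 1110 nM
- compound 2 `O=C(COc1ccc(CN2CC=C(c3c[nH]c4ccc(F)cc34)CC2)c(F)c1)NO` gives 3860 nM

Compound 1 holds the lower of the two numbers, which makes it the stronger inhibitor of this pair. The next compound to be measured is compound 3 `Cc1ccc2[nH]cc(C3=CCN(Cc4ccc(OCC(=O)NO)cc4)CC3)c2c1`, and its change from compound 1 is methyl in place of fluoro on an aromatic carbon, in words methyl in place of fluoro on an aromatic carbon. Going by the values given here, the only measured step, a 3.5-fold higher number from compound 1 to compound 2 (0.54 log units; beyond the scatter), is modest in size and is a different swap, fluoro in place of hydrogen on an aromatic carbon. It shows that one small aromatic substituent can move the number in this series, but it gives no direction for methyl against fluoro. Among the compounds with values here, no measured pair tests that exchange directly. Taking compound 1 at 1110 nM as the anchor, no step beyond the scatter is expected, although a modest move either way remains possible. The expected step is a 1.1-fold higher number from compound 1 to compound 3 (0.03 log units; within the scatter). For compound 3 the estimated value is 1200 nM, with an expected range from 450 nM to 3000 nM.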

Compound 3, half-maximal inhibitory concentration: 3960 nM
Beside the measured number, compound 3's estimate is 3.3-fold (0.52 log units) below it, and the stated range ends below it.
By their numbers in this assay, from the lowest: compound 1; then compounds 2 and 3 (each within the scatter of the next).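

In this assay, the aromatic carbon that carries fluoro in compound 1, meta to a fused ring and para to a fused ring, responds to the group placed on it: methyl in place of fluoro gives a 3.6-fold higher number from compound 1 to compound 3 (0.55 log units; beyond the scatter), even though the swap exchanges one heavy atom for one heavy atom and changes neither the hydrogen-bond donor and acceptor counts nor the net charge. The earlier step, a 3.5-fold higher number from compound 1 to compound 2 (0.54 log units; beyond the scatter), was a fluoro in place of hydrogen at a different aromatic carbon, so it said nothing about this position; now a single-atom change at each of the two places raises the number beyond the scatter, and compound 1 stays lowest in this small set. No measurement on hand bears on the reason for this step.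

The compounds shown leave open how hydrogen, chloro, methoxy or a nitrile would read at this same carbon, and so whether fluoro is itself helpful here or methyl is simply unfavourable. They also leave open whether the step from fluoro to methyl would hold with other groups elsewhere on the shared core.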